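Swapping 2-hydroxyphenyl for cyclohexyl on the shared core

This account rests on a few compounds, and the source may have more. Where it says the series, first, only, none or still open, it means among the compounds named here.

Compound 1 `O=[N+]([O-])c1cc(C(F)(F)F)cc([N+](=O)[O-])c1Nc1ccccc1O`: > 50000 nM
Compound 2 `CN(C)c1c([N+](=O)[O-])cc(C(F)(F)F)cc1[N+](=O)[O-]`: > 50000 nM
Compound 3 `O=[N+]([O-])c1cc(C(F)(F)F)cc([N+](=O)[O-])c1Nc1cccc(O)c1`: 35000 nM

In an ADME assay on THP-1 cells (Homo sapiens) for cytotoxicity, read by flow cytometry and propidium iodide staining, with a stated time of 48 h (a higher number here means that more compound is tolerated, a lower number that less compound is tolerated), compound 1 gives > 50000 nM, which is a limit and not a number. Compound 2 gives > 50000 nM, which is also a limit. Among the measured compounds shown here, compound 3 gives 35000 nM, the only actual number so far. Compound 1 therefore stands at the limit of > 50000 nM in this assay, at which 2 of the 3 values shown sit.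

Compound 4 `O=[N+]([O-])c1cc(C(F)(F)F)cc([N+](=O)[O-])c1NC1CCCCC1` has not yet been measured. The change leading to it is cyclohexyl in place of 2-hydroxyphenyl on a nitrogen on an aromatic ring: the cut can also be read as (2-hydroxyphenyl)amino to cyclohexylamino.

For the measured compounds named here, three measured steps bear on this change, since each alters the same substituent on the shared core. The closest is an at least 1.4-fold lower number from compound 1 to compound 3 (0.15 log units; that floor lies within the scatter), in which 3-hydroxyphenyl takes the place of 2-hydroxyphenyl on the nitrogen. A second is an at least 1.4-fold lower number from compound 2 to compound 3 (0.15 log units; that floor lies within the scatter). The third is a step that the two limits leave unreadable from compound 1 to compound 2. None of them tests a cyclohexyl group.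

No step beyond the scatter is therefore expected in this assay, although a small move towards a lower number is plausible given that compound 3 reads 35000 nM. The expected step is an at least 1.4-fold lower number from compound 1 to compound 4 (0.15 log units; that floor lies within the scatter). Compound 4 is estimated at 35000 nM, with an expected range of 12000 nM to 70000 nM.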

Compound 4, half-maximal cytotoxic concentration: > 50000 nM
Compound 4: no number, only a limit (the forecaster's own chance of this, stated with the estimate: 45%); middle value at least 1.4-fold (0.15 log units) from the limit.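

In this assay compound 4 gives > 50000 nM as a limit of the assay and not a number. Among the compounds shown here, the steps from compound 1 and from compound 2 to compound 4 cannot be read, since both ends are limits, and the one readable step is an at least 1.4-fold higher number from compound 3 to compound 4 (0.15 log units; that floor lies within the scatter), so no real difference between the cyclohexyl and 3-hydroxyphenyl groups on this nitrogen can be claimed. What compound 4 adds is that a non-aromatic carbon ring with no hydrogen-bond donor or acceptor also sits at the limit shared with the 2-hydroxyphenyl group of compound 1 and the dimethylamino group of compound 2, so that this change brings no readable loss of tolerance and the position stays largely flat: the limit of > 50000 nM in this assay, at which 3 of the 4 values shown sit.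

From the compounds shown here alone, how far compounds 1, 2 and 4 lie beyond that limit stays unknown, and with it any ranking among them or against compound 3. Going by these compounds, it also remains open whether a carboxylic acid or a primary amine on the ring, or a longer chain such as n-octyl on the nitrogen, would give a number that can be read at this position.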